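Replacing 4-methoxyphenyl with 3-iodophenyl on the shared core

The compounds below may be only part of what the source reports. "The series", "measured", "known", "first", "only" and "open" are said of these compounds alone.

Of the compounds shown here, three sharing one core have been measured in a functional assay on MCF7 cells (Homo sapiens) for antiproliferative activity, read by MTT assay, with a stated time of 48 h; on this read-out lower numbers stand for stronger inhibition and higher numbers for weaker inhibition. Compound 1 `COc1ccc2nc(NC(c3cn(-c4ccccc4)nc3-c3ccc([N+](=O)[O-])cc3)c3c(O)ccc4ccccc34)sc2c1`, the nitro member, gives 13300 nM. Compound 2 `COc1ccc2nc(NC(c3cn(-c4ccccc4)nc3-c3ccc(F)cc3)c3c(O)ccc4ccccc34)sc2c1`, the fluoro member, gives 16900 nM. The two are separated by a 1.3-fold higher number from compound 1 to compound 2 (0.10 log units; within the scatter). Compound 3 `COc1ccc(-c2nn(-c3ccccc3)cc2C(Nc2nc3ccc(OC)cc3s2)c2c(O)ccc3ccccc23)cc1`, the methoxy member, gives 41800 nM, the highest number of the three and so the weakest inhibition in this small set.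

Compound 4 `COc1ccc2nc(NC(c3cn(-c4ccccc4)nc3-c3cccc(I)c3)c3c(O)ccc4ccccc34)sc2c1` has not yet been measured. It departs from compound 3 through (3-iodophenyl in place of 4-methoxyphenyl on an aromatic carbon), with 3-iodophenyl in place of 4-methoxyphenyl on an aromatic carbon. The closest evidence comes from the two steps ending at the methoxy member, a 3.1-fold higher number from compound 1 to compound 3 (0.50 log units; beyond the scatter) and a 2.5-fold higher number from compound 2 to compound 3 (0.39 log units; beyond the scatter). Both are modest, and both show methoxy giving a higher number than the other two substituents. Going by the values given here, no measured compound carries iodine, so fluoro compound 2 at 16900 nM is only an approximate guide. Losing the methoxy group is therefore expected to bring a modest move towards a lower number in this assay, though the range must stay wide. The expected step is a 2.2-fold lower number from compound 3 to compound 4 (0.34 log units; beyond the scatter). The estimate for compound 4 is 19000 nM, with an expected range from 8000 nM to 42000 nM.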

Compound 4, half-maximal inhibitory concentration: 20000 nM
Beside the measured number, compound 4's estimate is 1.1-fold (0.02 log units) below it; the range from low to high includes it.
By their numbers in this assay, from the lowest: compounds 1, 2 and 4 (each within the scatter of the next); then compound 3.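

In this assay, 3-iodophenyl in place of 4-methoxyphenyl on this aromatic carbon of the five-membered ring gives (a 2.1-fold lower number from compound 3 to compound 4 (0.32 log units; beyond the scatter)), so a second kind of change at this position now lowers the number relative to compound 3, which remains the weakest of the four. Compound 4 cannot be told apart from the other two members, with (a 1.2-fold higher number from compound 2 to compound 4 (0.07 log units; within the scatter)) and (a 1.5-fold higher number from compound 1 to compound 4 (0.18 log units; within the scatter)), which shows that a ring bearing iodine at a different ring position fits among the 4-fluorophenyl and 4-nitrophenyl members rather than with the 4-methoxyphenyl member. Nothing in the data shown explains this result.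

The step changes both the substituent and its ring position at once, so these compounds cannot show whether the iodine or its position matters, or whether 4-iodophenyl and 3-methoxyphenyl would follow compound 4 or compound 3. They also leave open how an unsubstituted phenyl, or a phenyl bearing an amine or a carboxylic acid, would behave at this position, since all four numbers shown come from neutral aryl groups in this one cell assay.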